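Removing a fluorine from the aniline of compound 2

This account rests on a few compounds, and the source may have more. Where it says the series, first, only, none or still open, it means among the compounds named here.

Of the compounds shown here, three sharing one core have been tested in a functional assay on cells (Panel leukemia (Carcinoma cell lines), Homo sapiens) for inhibition, read by sulforhodamine B assay, with a stated time of 48 h; a lower number here means that less compound is tolerated, a higher number that more compound is tolerated. Compound 1 `CN1CCN(CCCOc2cccc3nc(Nc4ccc(Cl)c(C(F)(F)F)c4)ccc23)CC1` gives 7780 nM, compound 2 `CN1CCN(CCCOc2cccc3nc(Nc4ccc(Cl)c(F)c4)ccc23)CC1` gives 53900 nM, and compound 3 `CN1CCN(CCCOc2cccc3nc(Nc4cc(Cl)cc(Cl)c4)ccc23)CC1` gives 100000 nM. Compound 2 thus holds the second highest number of the three: it is a 6.9-fold higher number from compound 1 to compound 2 (0.84 log units; beyond the scatter), while a 1.9-fold higher number from compound 2 to compound 3 (0.27 log units; within the scatter).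

Compound 4 `CN1CCN(CCCOc2cccc3nc(Nc4cccc(Cl)c4)ccc23)CC1` differs from compound 2 by 3-chlorophenyl in place of 4-chloro-3-fluorophenyl on a nitrogen on an aromatic ring. Among the compounds with values here, no measured step removes a fluorine alone; the nearest evidence is that a 6.9-fold higher number from compound 1 to compound 2 (0.84 log units; beyond the scatter), where a smaller group went with a higher number, and that a 1.9-fold higher number from compound 2 to compound 3 (0.27 log units; within the scatter). A small rise or no change beyond the scatter is therefore expected, so that a 1.4-fold higher number from compound 2 to compound 4 (0.14 log units; within the scatter) is anticipated. Compound 4 is estimated at 75000 nM, within 30000 nM to 100000 nM.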

Compound 4, concentration lethal to 50% of the cells: 38000 nM
The estimate for compound 4 lay 2.0-fold (0.30 log units) above the measured number; measured number inside the range.
By their numbers in this assay, from the lowest: compound 1; then compounds 4, 2 and 3 (each within the scatter of the next, the first and the last beyond it).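

In this assay, the 4-chloro-3-fluorophenyl group can lose its fluorine without a change that clears the scatter: a 1.4-fold lower number from compound 2 to compound 4 (0.15 log units; within the scatter). Losing a chloro does register, with hydrogen in place of chloro giving a 2.6-fold lower number from compound 3 to compound 4 (0.42 log units; beyond the scatter), and the trifluoromethyl-bearing group of compound 1 still stands apart, with a 4.9-fold higher number from compound 1 to compound 4 (0.69 log units; beyond the scatter). Nothing available explains why these steps differ in size. On these data alone, whether a methoxy group or a nitrile in place of the chloro of the 3-chlorophenyl group would hold the number near that of compound 4 remains open.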